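The source may hold more compounds than are shown below. What is called first, only, known or untested is meant among the compounds shown, and "the series" means these compounds.

In an ADME assay (liver) for metabolic stability, with Liver microsome (Rattus norvegicus) as the target, using microsomes and NADPH, with a stated time of 30 min (a higher number here means faster removal of the compound, a lower number slower removal), two compounds built on a shared core have been measured so far. Compound 1 (`CC#C[C@H]1CN(S(=O)(=O)c2ccc(N)nc2)CCN1c1ccc(S(=O)(=O)NC)cn1`) gives 42 mL.min-1.g-1, and compound 2 (`CC#C[C@H]1CN(S(=O)(=O)c2ccc(N)nc2)CCN1c1ccc(S(N)(=O)=O)cc1`) gives 30 mL.min-1.g-1. These two numbers lie within the usual scatter of each other, so compound 2 stands level with compound 1 on this evidence. The pair differs in more than one place, and no single structural change can be read from it.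

Compound 3 (`CC#C[C@H]1CN(S(=O)(=O)c2ccc(N)nc2)CCN1c1ccc(S(C)(=N)=O)cc1`) has not yet been measured. It departs from compound 2 in one place, on an aromatic carbon, para to a large group, where the sulfamoyl leaves: a group of 4 heavy atoms (1 carbon, 1 nitrogen, 1 oxygen, 1 sulfur; no ring) in place of a group of 4 heavy atoms (1 nitrogen, 2 oxygen, 1 sulfur; no ring), on an aromatic carbon. For the measured compounds named here, no measured step of this kind is available, so no step beyond the scatter is expected in this assay. The expected change is a 1.2-fold higher number from compound 2 to compound 3 (0.07 log units; within the scatter). For compound 3 the estimated value is 35 mL.min-1.g-1, with an expected range of 18 mL.min-1.g-1 to 65 mL.min-1.g-1.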

Compound 3, intrinsic clearance in microsomes: < 14 mL.min-1.g-1
Compound 3 gave a limit, no number (the forecaster's own chance of this, stated with the estimate: 5%); middle value at least 2.5-fold (0.39 log units) away from the limit.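

In this assay, the earlier pair differed in more than one place and showed no effect of any single change. The exchange of the sulfamoyl for the new group on this aromatic carbon, para to a large group, now gives an at least 2.1-fold lower number from compound 2 to compound 3 (0.33 log units; beyond the scatter), even though both groups have equal counts of heavy atoms, hydrogen-bond donors and hydrogen-bond acceptors. The result for compound 3 is a limit of the assay and not a number, so the step has a bound but no exact size: the limit of < 14 mL.min-1.g-1 in this assay, at which 1 of the 3 values shown sits.

The compounds shown leave open how far compound 3 actually lies from compound 2 and whether the same exchange would have a similar effect on the core of compound 1. They also do not show how a methyl sulfone, a nitrile or a carboxylic acid would read at this position.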